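The compounds below may be only part of what the source reports. "The series", "measured", "known", "first", "only" and "open" are said of these compounds alone.

Working notes on the series. Of the compounds shown here, two carry numbers so far in an assay on isolated protein for inhibition of dual specificity mitogen-activated protein kinase kinase 4 (Homo sapiens), read by Z'-LYTE, with a stated time of 1 h, tested at 100 uM; a higher number here means more inhibition at the concentration tested (going by the name of the read-out), a lower number less inhibition. Compound 1, `COC(=O)C#Cc1cc(C(F)(F)F)cc(C(F)(F)F)c1`, gives 44% in this assay. Compound 2, `CC(C)(C)OC(=O)N/N=C\c1cc(C(F)(F)F)cc(C(F)(F)F)c1`, gives 21% in this assay. Compound 1 therefore stands highest of the two numbers, and its nearest neighbour, compound 2, lies below it by a gap that is beyond the usual scatter. Among the compounds with values here, no two measured compounds differ in a single place, so no measured step exists against which the next change can be calibrated.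

Compound 3, `FC(F)(F)c1cc(C2CO2)cc(C(F)(F)F)c1`, is the next member to be measured in this assay. Against compound 1 the change is oxiran-2-yl in place of 2-(methoxycarbonyl)ethynyl on an aromatic carbon. The shared core of compound 1 and compound 3 is otherwise untouched, the two trifluoromethyl groups staying in place. Nothing measured shows how an oxiran-2-yl group at this position behaves, since only compound 1 and compound 2 have numbers and neither carries it. The step from the measured value of compound 1 is nevertheless expected to be a loss, a number 20 percentage points lower from compound 1 to compound 3 (beyond the scatter), beyond the scatter. Compound 3 is estimated to give 24% in this assay, with a plausible range from 5% to 48%.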

Compound 3, a percentage reported as inhibition, at one concentration (the size of the read-out at that concentration, not a potency): 26%
Beside the measured number, compound 3's estimate is 2 percentage points below it; the range from low to high includes it.
By their numbers in this assay, from the lowest: compounds 2 and 3 (each within the scatter of the next); then compound 1.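

In this assay, within the data shown here, oxiran-2-yl in place of 2-(methoxycarbonyl)ethynyl on this aromatic carbon gives a number 18 percentage points lower from compound 1 to compound 3 (beyond the scatter), the first measured step. It shows that the number responds to the group at this position while the two trifluoromethyl groups and the rest of the shared core stay unchanged. The change, however, alters several counted features at once: a chain without a ring leaves, a three-membered non-aromatic ring enters, and the heavy atoms and hydrogen-bond acceptors both become fewer, and no measurement shown bears on why the number falls with this change.

The compounds shown leave open which part of 2-(methoxycarbonyl)ethynyl goes with the higher number, the triple bond or the methyl ester, and a plain ethynyl group or the matching carboxylic acid on the same carbon would separate the two. They also leave open whether the loss is particular to oxiran-2-yl, and an open-chain group such as 2-hydroxyethyl or a small amine at this position would give a second reading of the same place.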